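A few compounds are considered here, and "the series" means these few. Any claim that something is new, unique, unknown or untested is made for them only; others in the source may bear on it.

Compound 1 `CCOc1cc(C(C)(C)C)ccc1C1=NC(c2ccc(Cl)cc2)C(c2ccc(Cl)cc2)N1C(=O)NCCCCCCCC(=O)Nc1ccccc1N`: 19600 nM
Compound 2 `CCOc1cc(C(C)(C)C)ccc1C1=NC(c2ccc(Cl)cc2)C(c2ccc(Cl)cc2)N1C(=O)NCCCCCCCC(=O)NO`: 9060 nM

Among the measured compounds shown here, in a functional assay on NCI-H1299 cells (Homo sapiens) for antiproliferative activity, read by CCK-8 assay, with a stated time of 72 h (a higher number here means a weaker inhibitor, a lower number a stronger inhibitor), compound 2 at 9060 nM holds the lower of the two numbers, and its only neighbour is compound 1 at 19600 nM. The next compound, compound 3 `CCOc1cc(C(C)(C)C)ccc1C1=NC(c2ccc(Cl)cc2)C(c2ccc(Cl)cc2)N1C(=O)NCCCCCCC(=O)Nc1ccccc1N`, is still unmeasured. The change from compound 2 is (2-aminophenyl)carbamoyl in place of (hydroxycarbamoyl)methyl on a saturated chain carbon, six bonds along the chain from an amide-type nitrogen. For the measured compounds named here, the one measured step that bears on it is a 2.2-fold lower number from compound 1 to compound 2 (0.34 log units; beyond the scatter), a modest move that compound 3 would largely reverse, since it carries the end group of compound 1. Going by the values given here, no measured pair isolates the difference in chain, so this remains uncertain. A rise of similar modest size is therefore expected. The estimated step is a 2.1-fold higher number from compound 2 to compound 3 (0.32 log units; beyond the scatter). For compound 3 the expected value is 19000 nM, with an estimated range of 8000 nM to 45000 nM.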

Compound 3, half-maximal inhibitory concentration: 17500 nM
Estimate against measurement, compound 3: 1.1-fold (0.04 log units) above, and the stated range covers the measured number.
By their numbers in this assay, from the lowest: compounds 2, 3 and 1 (each within the scatter of the next, the first and the last beyond it).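

In this assay, placing (2-aminophenyl)carbamoyl in place of ((2-aminophenyl)carbamoyl)methyl, on a saturated chain carbon six bonds along the chain from an amide-type nitrogen, gives a 1.1-fold lower number from compound 1 to compound 3 (0.05 log units; within the scatter), so with this end group the change of chain produces no difference the assay can separate. The swap to (2-aminophenyl)carbamoyl from (hydroxycarbamoyl)methyl at the same place gives a 1.9-fold higher number from compound 2 to compound 3 (0.29 log units; within the scatter), so compound 3 cannot be ordered against either of the others, although a 2.2-fold lower number from compound 1 to compound 2 (0.34 log units; beyond the scatter) separates those two. No measurement on hand explains these numbers.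

The compounds shown leave open whether the same change of chain would behave alike with the hydroxy end group of compound 2. They also leave open whether a longer chain, or a carboxylic acid at the chain end, would move the number beyond the scatter.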